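Pyridin-4-yl to pyrimidin-2-yl on the amine nitrogen

The source may report more compounds than this note shows. Statements on the series, on what has been measured and on what is new or still open speak of the compounds shown alone.

Compound 1 `C[C@@H](Cn1ccc(-c2ccc(C#N)c(Cl)c2)n1)Nc1cccnc1`: > 30000 nM (a limit of the assay)
Compound 2 `C[C@@H](Cn1ccc(-c2ccc(C#N)c(Cl)c2)n1)Nc1ccncc1`: 9900 nM

For the measured compounds named here, in a functional assay on VCaP cells (Homo sapiens) for antiproliferative activity, read by CCK-8 assay, with a stated time of 6 days (a higher number here means a weaker inhibitor, a lower number a stronger inhibitor), compound 2 gives 9900 nM, the only true number so far. Compound 1 reports only a limit, > 30000 nM. The next structure, compound 3 `C[C@@H](Cn1ccc(-c2ccc(C#N)c(Cl)c2)n1)Nc1ncccn1`, differs from compound 2 in one ring: pyrimidin-2-yl in place of pyridin-4-yl on an amine nitrogen. Thus pyrimidin-2-yl stands in place of pyridin-4-yl on an amine nitrogen. Going by the values given here, one measured step bears on this change: an at least 3.0-fold lower number from compound 1 to compound 2 (0.48 log units; beyond the scatter). From the compounds shown here alone, its full size stays open because of the limit of > 30000 nM in this assay, at which 1 of the 2 values shown sits. The step of an at least 3.0-fold lower number from compound 1 to compound 2 (0.48 log units; beyond the scatter) favours the pyridin-4-yl ring that compound 3 gives up, so a modest move toward a higher number is expected in this assay. The expected change is a 1.7-fold higher number from compound 2 to compound 3 (0.23 log units; within the scatter). For compound 3 the estimated value is 17000 nM, with an expected range of 7000 nM to 30000 nM.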

Compound 3, half-maximal inhibitory concentration: 480 nM
Compound 3: middle estimate off by 35-fold (1.55 log units), on the high side, outside the stated range (below it).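

In this assay, for the compounds shown here, the ring on the amine nitrogen turns out to be a strong determinant of the read-out, and the pyridine pair alone gave no sign of a step this large: pyrimidin-2-yl in place of pyridin-4-yl gives a 21-fold lower number from compound 2 to compound 3 (1.31 log units; beyond the scatter). Against the other pyridine, the same ring gives an at least 62-fold lower number from compound 1 to compound 3 (1.79 log units; beyond the scatter), which makes compound 3 the strongest inhibitor of the three. Compound 1 carries only a limit, so the full size of that second step stays open: the limit of > 30000 nM in this assay, at which 1 of the 3 values shown sits.

The compounds shown cannot tell whether the step follows the count of hetero atoms in the ring or where they sit; a pyridin-2-yl, pyrazin-2-yl or pyrimidin-4-yl ring on the same amine nitrogen would separate the two. From the compounds shown here alone, whether the amine hydrogen is needed also stays open, a question that an N-methyl amine would address.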